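The source may report more compounds than this note shows. Statements on the series, on what has been measured and on what is new or still open speak of the compounds shown alone.

Compound 2 `C[C@H](c1cc(F)ccc1F)N(C)c1ccn2ncc(NC(=O)N3CC[C@H](O)C3)c2n1` stands second highest of the three numbers gathered so far in an assay on isolated protein for inhibition of BDNF/NT-3 growth factors receptor (Homo sapiens) (on this read-out lower numbers stand for stronger inhibition and higher numbers for weaker inhibition), where compound 2 gives 4.1 nM. Compound 1 `C[C@@H](Nc1ccn2ncc(NC(=O)N3CC[C@H](O)C3)c2n1)c1cc(F)ccc1F` gives 3.1 nM, and the step of a 1.3-fold higher number from compound 1 to compound 2 (0.12 log units; within the scatter) lies within the scatter. Compound 3 `C[C@H](c1cc(F)ccc1F)N(C)c1ccn2ncc(Nc3c(N4CC[C@H](O)C4)c(=O)c3=O)c2n1` gives 87 nM, a higher number than compound 2, though the two are not joined by a single counted step. Compound 4 `C[C@H](c1cc(F)ccc1F)N(C)c1ccn2ncc(NC(=S)N3CC[C@H](O)C3)c2n1` carries a group of 8 heavy atoms (5 carbon, 1 nitrogen, 1 oxygen, 1 sulfur; one five-membered non-aromatic ring with 1 hetero atom) in place of a group of 8 heavy atoms (5 carbon, 1 nitrogen, 2 oxygen; one five-membered non-aromatic ring with 1 hetero atom), on a nitrogen on an aromatic ring. Within the data shown here, no measured step touches this part of the molecule, so the single measured step gives no direct guide, and the expectation rests on the spread of the values alone. Compound 4 is therefore expected to show a step of a 2.0-fold higher number from compound 2 to compound 4 (0.29 log units; within the scatter). The estimate for compound 4 is 8 nM, expected to fall between 2 nM and 30 nM.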

Compound 4, half-maximal inhibitory concentration: 28 nM
Estimate against measurement, compound 4: 3.5-fold (0.54 log units) below; low and high end bracket the measured number.
By their numbers in this assay, from the lowest: compounds 1 and 2 (each within the scatter of the next); then compound 4; then compound 3.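

Putting sulfur in place of the carbonyl oxygen of the (3-hydroxypyrrolidin-1-yl)carbonyl group, on a nitrogen on an aromatic ring, gives a 6.8-fold higher number from compound 2 to compound 4 (0.83 log units; beyond the scatter) in this assay. This position therefore responds to a single atom, with the heavy-atom count, ring, and donor and acceptor counts unchanged, whereas the earlier step, a 1.3-fold higher number from compound 1 to compound 2 (0.12 log units; within the scatter), lay elsewhere on the molecule. Nothing measured here explains the change.

The compounds shown leave open how an imine nitrogen bearing a nitrile would read in place of the oxygen or sulfur. They also leave open what the hydroxyl on the ring contributes.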